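From pyridin-4-yl to oxan-4-yl on the shared core

A few compounds are considered here, and "the series" means these few. Any claim that something is new, unique, unknown or untested is made for them only; others in the source may bear on it.

Compound 1 `CS(=O)(=O)NC(=O)CCc1cn(-c2ccc(Cl)cc2)nc1-c1ccc(Cl)cc1` gives 0.00023
Compound 2 `CS(=O)(=O)NC(=O)CCc1cn(-c2ccc(Br)cc2)nc1-c1ccncc1` gives 0.00009

In an ADME assay on a cell-free system (plasma, Homo sapiens) for protein binding, read by LC-MS, tested at 5 uM (a lower number here means a smaller unbound share, a higher number a larger unbound share of the compound), compound 2 gives 0.00009 and holds the lower of the two numbers, a gap from compound 1 (0.00023) that lies beyond the scatter. Both compounds have only a very small unbound share. Compound 3 `CS(=O)(=O)NC(=O)CCc1cn(-c2ccc(Br)cc2)nc1C1CCOCC1` has not been measured yet. It carries oxan-4-yl in place of pyridin-4-yl on an aromatic carbon. Within the data shown here, no two measured compounds differ in just one place, so the data offer no direct guide to this swap. A modest rise in the unbound fraction is expected, starting from compound 2 (0.00009), and the number should stay very small. The estimated change is a 2.8-fold higher number from compound 2 to compound 3 (0.44 log units; beyond the scatter) and remains uncertain. For compound 3 the estimate is 0.00025 (expected range 0.00009 to 0.0007).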

Compound 3, unbound fraction: 0.0007
The estimate for compound 3 lay 2.8-fold (0.45 log units) below the measured number, and the stated range covers the measured number.
By their numbers in this assay, from the lowest: compound 2; then compound 1; then compound 3.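

In this assay, among these compounds, oxan-4-yl in place of pyridin-4-yl gives a 7.8-fold higher number from compound 2 to compound 3 (0.89 log units; beyond the scatter), the only step here that changes one place alone. It shows that the group on this aromatic carbon of the five-membered ring can shift the unbound share clearly, even though the two groups match in heavy atoms, ring size, hydrogen-bond donors and hydrogen-bond acceptors, and differ in whether the ring is aromatic and in its hetero atom, nitrogen or oxygen. No measurement at hand tells why the number rises.

Still open, as far as these compounds go, is which of those two differences matters, and a cyclohexyl ring or a phenyl ring on the same carbon could help separate them. From the compounds shown here alone, it is also open whether the same swap would give a similar step with a 4-chlorophenyl group in place of the 4-bromophenyl group.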